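Trimming One Ester from Isopropyl to Ethyl

The source may hold more compounds than are shown below. What is called first, only, known or untested is meant among the compounds shown, and "the series" means these compounds.

Measured so far:
compound 1 `CSc1ncc(C2C(C(=O)OC(C)C)=C(C)NC(C)=C2C(=O)OC(C)C)n1Nc1ccccc1`, 2.16 nM
compound 2 `CSc1ncc(C2C(C(=O)OCc3ccccc3)=C(C)NC(C)=C2C(=O)OCc2ccccc2)n1Nc1ccccc1`, 1.49 nM
compound 3 `CCCOC(=O)C1=C(C)NC(C)=C(C(=O)OC)C1c1cnc(SC)n1Nc1ccccc1`, 2.4 nM

All three were tested in an assay on isolated protein (strain albino) for antagonist activity at Voltage-dependent L-type calcium channel subunit alpha-1C (Cavia porcellus); on this read-out lower numbers stand for stronger inhibition and higher numbers for weaker inhibition. Compound 1 holds the second highest of the three numbers; compound 3 stands nearest to it and compound 2 furthest, but both gaps lie within the scatter, so no ordering among them can be claimed. Compound 4 `CCOC(=O)C1=C(C)NC(C)=C(C(=O)OC(C)C)C1c1cnc(SC)n1Nc1ccccc1` has not been measured. It differs from compound 1 in one place: hydrogen in place of methyl on a saturated chain carbon bound to an oxygen next to a carbonyl group and a saturated chain carbon. Among the compounds with values here, no single step of this kind has been measured, yet the varied ester chains across compounds 1, 2 and 3 all give numbers within the scatter of each other. Compound 4 is therefore expected to follow suit: a 1.1-fold higher number from compound 1 to compound 4 (0.03 log units; within the scatter), nothing beyond the scatter. The estimate for compound 4 is 2.3 nM, between 1 nM and 5 nM.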

Compound 4, half-maximal inhibitory concentration: 3.22 nM
Compound 4: the middle estimate sits 1.4-fold (0.15 log units) below what was measured; the range from low to high includes it.
By their numbers in this assay, from the lowest: compounds 2, 1, 3 and 4 (each within the scatter of the next, the first and the last beyond it).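

Within the data shown here, this is the first single-place step at this ester: in this assay, isopropyl to ethyl gives a 1.5-fold higher number from compound 1 to compound 4 (0.17 log units; within the scatter). Losing one methyl on this saturated chain carbon therefore leaves the number within the scatter, something the earlier compounds, which differ in more than one place, could not show directly. Nothing on hand bears on the reason for this result.

The compounds shown leave open whether a carboxylic acid, an amide or a much longer chain in place of this ester would also stay within the scatter of compound 1.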